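Compound 3 to compound 4: a chlorophenyl swap

This account rests on a few compounds, and the source may have more. Where it says the series, first, only, none or still open, it means among the compounds named here.

Measured so far in a functional assay on Bel-7402 cells (Homo sapiens) for inhibition, read by MTT assay, with a stated time of 24 h, tested at 1 ug/mL; on this read-out higher numbers stand for more inhibition of growth at the one concentration tested and lower numbers for less inhibition of growth:
- compound 1 `O=C(CCCCC(S)CCS)Nc1ccccc1`: 1.32%
- compound 2 `CC(=O)SCCC(CCCCC(=O)Nc1ccccc1)SC(C)=O`: 2.84%
- compound 3 `CC(=O)SCCC(CCCCC(=O)Nc1ccccc1Cl)SC(C)=O`: 5.01%

All three compounds show little inhibition of growth at the one concentration tested. In this assay compound 3 gives 5.01%, and this number cannot be told apart from those of compound 1 and compound 2, since the gaps to both lie within the scatter.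

The next compound to be tested is compound 4 `CC(=O)SCCC(CCCCC(=O)Nc1ccc(Cl)cc1)SC(C)=O`. It has the same atoms as compound 3, joined differently: 4-chlorophenyl in place of 2-chlorophenyl on an amide-type nitrogen. In words, 4-chlorophenyl stands in place of 2-chlorophenyl on an amide-type nitrogen, and the rest of the molecule stays the same.

Among the compounds with values here, no measured pair shows this exact change. The closest evidence is the step that puts chloro in place of hydrogen on an aromatic carbon, a number 2.2 percentage points higher from compound 2 to compound 3 (within the scatter). Introducing the chloro left the read-out within the scatter, so there is no basis for expecting that relocating it will do more. The estimated step is a number 0 percentage points lower from compound 3 to compound 4 (within the scatter), which means no change beyond the scatter is expected. For compound 4 the estimated value is 5%, with an expected range from 0% to 13%.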

Compound 4, percent growth inhibition at one concentration: 3.07%
Compound 4: the middle estimate sits 1.9 percentage points above what was measured; low and high end bracket the measured number.
By their numbers in this assay, from the lowest: compounds 1, 2, 4 and 3 (each within the scatter of the next).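

In this assay, within the data shown here, moving the chlorine from the 2-chlorophenyl to the 4-chlorophenyl arrangement on the amide-type nitrogen gives a number 1.9 percentage points lower from compound 3 to compound 4 (within the scatter), the first direct look at where the chlorine sits on this ring, and that move cannot be told from no change. Compared with the plain phenyl group, the 4-chlorophenyl group gives a number 0.2 percentage points higher from compound 2 to compound 4 (within the scatter), so with both chlorine placements now within the scatter of the unsubstituted parent, neither adding the chlorine nor relocating it shows a readable effect in these compounds. No supporting measurement is available to say why the read-out stays this flat.

All four compounds show little inhibition of growth at the one concentration tested, so this series offers no clear signal against which a small ring change could stand out. Still open, as far as these compounds go, is whether a different kind of group, such as an amine or a carboxylic acid on the phenyl ring, or a longer chain in place of the present one, would move the number beyond the scatter.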